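The compounds below may be only part of what the source reports. "The series", "measured", "known", "first", "only" and "open" are said of these compounds alone.

Compound 1 `CC1CC(=O)N(c2ccccc2C(=O)OCC2CCCN(CCCCCc3ccccc3)C2)C1=O`: 24500 nM in an in vitro functional assay on HEK ts201 cells for antagonist activity at Neuronal acetylcholine receptor; alpha4/beta2 (Homo sapiens), read by fluorescence and calcium flux; a higher number here means a weaker inhibitor, a lower number a stronger inhibitor. Compound 2 `COc1cccc(OCCCCCN2CCCC(COC(=O)c3ccccc3N3C(=O)CC(C)C3=O)C2)c1OC`: 8710 nM in this assay.

Going by the values given here, compound 1 holds the higher of these two numbers, and its only neighbour is reached by a 2.8-fold lower number from compound 1 to compound 2 (0.45 log units; beyond the scatter). Compound 3 `CC1CC(=O)N(c2ccccc2C(=O)OCC2CCCN(CCCC3CCCCC3)C2)C1=O` differs from compound 1 by cyclohexyl in place of phenethyl on a saturated chain carbon, three bonds along the chain from an amine nitrogen in a ring. Among the compounds with values here, the one measured step swapped the group on a saturated chain carbon five bonds along the chain from an amine nitrogen in a ring, which is a different kind of change, so it bears only loosely here. A step of a 1.0-fold lower number from compound 1 to compound 3 (0.01 log units; within the scatter) is therefore expected, within the scatter. Compound 3 is estimated at 24000 nM, ranging from 8000 nM to 70000 nM.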

Compound 3, half-maximal inhibitory concentration: 14500 nM
For compound 3 the middle estimate is 1.7-fold (0.22 log units) above the measured one, within the range that was stated.
By their numbers in this assay, from the lowest: compounds 2, 3 and 1 (each within the scatter of the next, the first and the last beyond it).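

In this assay, cyclohexyl in place of phenethyl gives a 1.7-fold lower number from compound 1 to compound 3 (0.23 log units; within the scatter) at this position, three bonds along the chain from an amine nitrogen in a ring. An end group with a non-aromatic ring and fewer heavy atoms therefore reads the same as the aromatic one here, within the scatter, which the earlier pair could not show. Nothing available explains this result.

Going by these compounds, whether a longer chain ending in cyclohexyl would shift the number remains open. So does the effect of an amine or a carboxylic acid on that ring.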